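This account rests on a few compounds, and the source may have more. Where it says the series, first, only, none or still open, it means among the compounds named here.

Compound 1 `OCc1cn(Cc2ccccc2)c2ccccc12`: 112 nM
Compound 2 `OCc1cn(Cc2ccc(Cl)cc2)c2ccccc12`: 16 nM

In a functional assay on NCI-H460 cells (Homo sapiens) for cytotoxicity, read by sulforhodamine B assay, with a stated time of 3 days (on this read-out lower numbers stand for stronger inhibition and higher numbers for weaker inhibition), compound 1 gives 112 nM, the highest of the two numbers shown. Compound 2 gives 16 nM. Compound 3 `OCc1cn(Cc2cccc(C(F)(F)F)c2)c2ccccc12` differs from compound 1 in one place: trifluoromethyl in place of hydrogen on an aromatic carbon. For the measured compounds named here, the only measured step that bears on this is a 7.0-fold lower number from compound 1 to compound 2 (0.85 log units; beyond the scatter), which concerns a different group at a different place on the same ring, so it guides only loosely. A smaller lowering is therefore expected, with a wide range. For compound 3 the estimate is 40 nM, between 10 nM and 160 nM. This corresponds to an expected step of a 2.8-fold lower number from compound 1 to compound 3 (0.45 log units; beyond the scatter).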

Compound 3, half-maximal inhibitory concentration: 39 nM
Compound 3: middle estimate off by 1.0-fold (0.01 log units), on the high side; the range from low to high includes it.
By their numbers in this assay, from the lowest: compound 2; then compound 3; then compound 1.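

In this assay, trifluoromethyl on an aromatic carbon, meta to a large group, gives a 2.9-fold lower number from compound 1 to compound 3 (0.46 log units; beyond the scatter). So chloro in compound 2 is not the only change on this ring that lowers the number: a second group, at a different place, does so too, though the step is smaller than a 7.0-fold lower number from compound 1 to compound 2 (0.85 log units; beyond the scatter). Nothing shown gives a reason for either lowering.

As far as these compounds go, it remains open whether an amine or a carboxylic acid at this same place would lower the number as well. Also open, from the compounds shown here alone, is how trifluoromethyl would fare at the place chloro holds in compound 2.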